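The source may report more compounds than this note shows. Statements on the series, on what has been measured and on what is new or still open speak of the compounds shown alone.

Compound 1, with the structure `CO[C@H]1CC[C@H](n2nc(Oc3cc(C(F)(F)F)ccn3)c3c(N)ncnc32)CC1`, is the starting point of this comparison. In an ADME assay on microsomes from liver (Mus musculus) for metabolic stability, read by LC-MS, using NADPH, with a stated time of 10 min, tested at 10 uM (on this read-out lower numbers stand for a shorter-lived compound and higher numbers for a longer-lived compound), compound 1 gives 0.217 h. Going by the values given here, that is the lower of the two numbers measured here: the only other compound, compound 2, with the structure `CC(C)(C)n1nc(Oc2cc(C#N)ccn2)c2c(N)ncnc21`, gives 0.767 h in this assay, and the gap between these two values is beyond the usual scatter of repeated measurements. Among the compounds with values here, no single-change step between measured compounds is available, so the two values say only that compound 2 is the longer-lived of the pair.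

The step under consideration leads from compound 1 to compound 3, whose structure is `CO[C@H]1CC[C@@H](n2nc(Oc3cc(C(F)(F)F)ccn3)c3c(N)ncnc32)CC1`. The change is the two compounds have the same atoms and bonds and differ only in configuration as drawn: 2 of 2 stereo elements differ (all stereocentres are inverted: mirror images); a stereocentre at a saturated ring carbon is drawn r in compound 1 and s in compound 3; a stereocentre at a saturated ring carbon is drawn r in compound 1 and s in compound 3. Within the data shown here, nothing among the measured compounds shows how inverting all stereocentres affects this assay, so no direction can be taken from the data. Compound 3 is therefore expected to give about 0.25 h, with a likely range from 0.1 h to 0.6 h. The expected step of a 1.2-fold higher number from compound 1 to compound 3 (0.06 log units; within the scatter) is estimated to stay within the usual scatter, in no clear direction.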

Compound 3, half-life: 0.0333 h
The estimate for compound 3 lay 7.5-fold (0.88 log units) above the measured number; the whole stated range lies above it.
By their numbers in this assay, from the lowest: compound 3; then compound 1; then compound 2.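

In this assay, going by these compounds alone, the change of configuration alone gives a 6.5-fold lower number from compound 1 to compound 3 (0.81 log units; beyond the scatter), the first step here that isolates a single change. The half-life therefore depends on how the two stereocentres at the saturated ring carbons are drawn, and not only on which atoms are present, because nothing else separates this pair: the fact that compounds 1 and 3 differ only in the configuration as drawn With the rest of the structure held fixed, the arrangement drawn in compound 1 is the longer-lived of the two, so configuration at this ring cannot be treated as a minor detail when comparing half-lives in this series.

As far as these compounds go, whether the same inversion would matter as much with a different group on the saturated ring, such as a hydroxyl or an amine in place of the methoxy, remains open, as does whether the gap would hold with a nitrile in place of the trifluoromethyl. The compounds shown also do not reveal which part of either molecule is lost in the microsomes, so the step describes a difference in half-life without showing how it arises.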